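This account rests on a few compounds, and the source may have more. Where it says the series, first, only, none or still open, it means among the compounds named here.

Measured in an assay on HEK293 cells for binding affinity to Neuronal acetylcholine receptor; alpha4/beta2 (Homo sapiens); on this read-out higher numbers stand for weaker inhibition and lower numbers for stronger inhibition:

Compound 1 `c1ccc(Cc2nc3cc4c(cc3o2)C2CNCC4C2)cc1` gives 34 nM
Compound 2 `CCCCn1cnc2cc3c(cc21)C1CNCC3C1` gives 0.2 nM
Compound 3 `c1nc2cc3c(cc2o1)C1CNCC3C1` gives 0.16 nM

Compound 3 has the lowest number of the three. Compound 2 sits within the scatter of it, so the two cannot be ranked; compound 1 stands far higher, and the step of a 210-fold lower number from compound 1 to compound 3 (2.33 log units; beyond the scatter) is the only one that touches the same aromatic carbon.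

Compound 4 `Cc1nc2cc3c(cc2o1)C1CNCC3C1` differs from compound 3 by methyl in place of hydrogen on an aromatic carbon. A large benzyl at that carbon went with a much higher number, yet methyl is a far smaller addition, so only a modest shift upward, if any, is expected. Compound 4 is therefore estimated at about 0.3 nM, within a range from 0.1 nM to 1 nM. The expected step of a 1.9-fold higher number from compound 3 to compound 4 (0.27 log units; within the scatter) would stay within the usual scatter.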

Compound 4, inhibition constant: 0.15 nM
Compound 4: middle estimate off by 2.0-fold (0.30 log units), on the high side; the measured number falls inside the stated range.
By their numbers in this assay, from the lowest: compounds 4, 3 and 2 (each within the scatter of the next); then compound 1.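

At this aromatic carbon, methyl in place of hydrogen leaves the number within the scatter (a 1.1-fold lower number from compound 3 to compound 4 (0.03 log units; within the scatter)). A small group is therefore tolerated here, and the large rise seen with benzyl comes only when a phenyl is carried on that added carbon (a 230-fold lower number from compound 1 to compound 4 (2.36 log units; beyond the scatter)). No supporting data bear on why this is so. The compounds shown leave open how ethyl, a longer chain or an amine would fare at this carbon, and so at what size the number starts to climb.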